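The source may hold more compounds than are shown below. What is called first, only, known or untested is meant among the compounds shown, and "the series" means these compounds.

Compound 3 `CC(C(=O)N1CCN(c2ccccc2C(F)(F)F)CC1)N1C(=O)CCC1=O` gives 100% in a functional assay on the whole organism (strain Swiss) with Mus musculus as the target, in the maximal electroshock model, with a stated time of 0.25 h, at a dose of 300 mg/kg by the intraperitoneal route (a lower number here means a weaker effect, a higher number a stronger effect of the compound at the dose given), level at the digits shown with compound 2 `CC(C(=O)N1CCN(c2ccc(F)cc2)CC1)N1C(=O)CCC1=O`, which gives 100%; both stand together at the top of the three numbers, while compound 1 `COc1cccc(N2CCN(C(=O)C(C)N3C(=O)CCC3=O)CC2)c1` gives 75%. Among the measured compounds shown here, the only measured step, a number 25 percentage points higher from compound 1 to compound 2 (beyond the scatter), concerns a different substitution on that ring and so bears only loosely on the present change. Compound 4 `CC(C(=O)N1CCN(c2ccccc2Cl)CC1)N1C(=O)CCC1=O` differs from compound 3 by chloro in place of trifluoromethyl on an aromatic carbon. Because compound 3 already shows 100%, the read-out has no room to rise, and the step of a number 5 percentage points lower from compound 3 to compound 4 (within the scatter) expected from compound 3 to compound 4 is none beyond the scatter. Compound 4 is therefore expected to give about 95%, within a range from 70% to 100%.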

Compound 4, a percentage reported as activity, at one dose (the size of the read-out at that dose, not a potency): 0%
For compound 4 the middle estimate is 95 percentage points above the measured one, outside the stated range (below it).
By their numbers in this assay, from the lowest: compound 4; then compound 1; then compounds 2 and 3 (each within the scatter of the next).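

In this assay the group on this aromatic carbon can decide between full effect and none: chloro in place of trifluoromethyl gives a number 100 percentage points lower from compound 3 to compound 4 (beyond the scatter). Among the compounds shown here, changing the whole aromatic substituent to 2-chlorophenyl also gives a number 100 percentage points lower from compound 2 to compound 4 (beyond the scatter) and a number 75 percentage points lower from compound 1 to compound 4 (beyond the scatter), far larger than the one step seen before, so the series is much more sensitive here than the earlier compounds suggested. No evidence at hand explains this loss. From the compounds shown here alone, whether bromo, methyl or methoxy on this same carbon would keep the effect stays open, as does how compound 4 behaves at other doses or times.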